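Fluoro for methyl on a shared pyrimidine-type scaffold

A few compounds are considered here, and "the series" means these few. Any claim that something is new, unique, unknown or untested is made for them only; others in the source may bear on it.

Measured compounds:
compound 1 `NS(=O)(=O)c1ccc(Nc2ncc(F)c(Nc3nc4ccccc4s3)n2)cc1` in a functional assay on PC-3 cells (Homo sapiens) for antiproliferative activity, read by MTT assay, with a stated time of 48 h (on this read-out lower numbers stand for stronger inhibition and higher numbers for weaker inhibition), gives > 50000 nM
compound 2 `COc1ccc2nc(Nc3nc(Nc4ccc(S(N)(=O)=O)cc4)ncc3C)sc2c1` in this assay gives > 50000 nM

Both values are limits of the assay rather than numbers; in this assay compound 2 sits at the limit, as does compound 1, so nothing distinguishes them (the limit of > 50000 nM in this assay, at which 2 of the 2 values shown sit). Compound 3 `COc1ccc2nc(Nc3nc(Nc4ccc(S(N)(=O)=O)cc4)ncc3F)sc2c1` differs from compound 2 in one place: fluoro in place of methyl on an aromatic carbon. Going by the values given here, no step between measured compounds exists to guide the size of this change, and compound 1, carrying fluoro, likewise reached only a limit. Compound 3 is therefore expected to remain near the limit as well, with the step from compound 2 to compound 3 estimated as a step that the limit leaves unreadable from compound 2 to compound 3. The estimate for compound 3 is 60000 nM, between 20000 nM and 200000 nM.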

Compound 3, half-maximal inhibitory concentration: > 50000 nM
Compound 3 was reported as a limit (the forecaster's own chance of this, stated with the estimate: 80%); the middle value lies beyond the limit too.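

No step can be read between compound 1, compound 2 and compound 3, because all three values are limits rather than numbers: the limit of > 50000 nM in this assay, at which 3 of the 3 values shown sit. The compounds shown leave open whether any change to the shared core gives a measurable value in this assay at all.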